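The source may report more compounds than this note shows. Statements on the series, on what has been measured and on what is new or still open speak of the compounds shown alone.

Measured compounds in an ADME assay on a cell-free system (plasma, Homo sapiens) for metabolic stability, with Plasma (Rattus norvegicus) as the target, read by HPLC, at pH 7.4; a higher number here means that the compound lasts longer, a lower number that the compound disappears faster:
compound 1, `CC(=O)Oc1ccccc1C(=O)O[C@H]1CO[C@H]2[C@@H]1OC[C@H]2OC(=O)c1ccccc1O`, half-life 0.0825 h
compound 2, `CC(=O)Oc1ccccc1C(=O)O[C@H]1CO[C@H]2[C@@H]1OC[C@H]2OC(C)=O`, half-life 0.0608 h
compound 3, `COc1ccccc1C(=O)O[C@@H]1CO[C@H]2[C@@H]1OC[C@@H]2OC(=O)c1ccccc1OC(C)=O`, half-life 0.0578 h

All three numbers sit within the scatter of one another. Compound 1 stands at the upper end of this narrow spread: the step of a 1.4-fold lower number from compound 1 to compound 2 (0.13 log units; within the scatter) and the step of a 1.4-fold lower number from compound 1 to compound 3 (0.15 log units; within the scatter) are both within the scatter, as is a 1.1-fold lower number from compound 2 to compound 3 (0.02 log units; within the scatter). Every change so far at the acyl group on the shared core, or at the oxygen on the aromatic ring, has left the number where it was.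

Compound 4, `CC(=O)Oc1ccccc1C(=O)O[C@H]1CO[C@H]2[C@@H]1OC[C@H]2OC(=O)c1ccncc1`, has not yet been measured in this assay. It differs from compound 1 as follows: pyridin-4-yl in place of 2-hydroxyphenyl on a carbonyl carbon. Going by the values given here, the steps that bear on this change are those that also exchange the group on the carbonyl carbon: methyl in place of 2-hydroxyphenyl in a 1.4-fold lower number from compound 1 to compound 2 (0.13 log units; within the scatter), and 2-methoxyphenyl in place of methyl in a 1.1-fold lower number from compound 2 to compound 3 (0.02 log units; within the scatter). Neither moved the number beyond the scatter. Among the compounds with values here, no step yet exchanges an aromatic carbon ring for a ring with a hetero atom, so that part of the change rests on nothing measured.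

On the steps available, the expected step is a 1.2-fold lower number from compound 1 to compound 4 (0.07 log units; within the scatter), that is, no change beyond the scatter. For compound 4 the estimate in this assay is 0.07 h, with a range from 0.035 h to 0.14 h.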

Compound 4, half-life: 0.0617 h
Compound 4: middle estimate off by 1.1-fold (0.05 log units), on the high side; the measured number falls inside the stated range.
By their numbers in this assay, from the lowest: compounds 3, 2, 4 and 1 (each within the scatter of the next).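

In this assay, going by these compounds alone, pyridin-4-yl is the first ring with a hetero atom on this carbonyl carbon, and it gives a 1.3-fold lower number from compound 1 to compound 4 (0.13 log units; within the scatter) in place of 2-hydroxyphenyl. The exchange therefore leaves the number where it was, even though the entering group has no hydrogen-bond donor and the leaving group has one. The other two comparisons at this place agree, with a 1.1-fold higher number from compound 3 to compound 4 (0.03 log units; within the scatter) for pyridin-4-yl in place of 2-methoxyphenyl and a 1.0-fold higher number from compound 2 to compound 4 (0.01 log units; within the scatter) for pyridin-4-yl in place of methyl, so these four groups on the carbonyl carbon cannot be told apart here. The data on hand offer nothing that accounts for this flat reading.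

Still open, going by these compounds, is whether any group at this place can move the number beyond the scatter, for example a phenyl ring carrying an amine or a carboxylic acid, or a longer chain in place of methyl. Also open, on these data alone, is whether pyridin-3-yl or pyridin-2-yl would read the same as pyridin-4-yl.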